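Adding a Second Chlorine to a Vinyl Sulfone Series

The source may hold more compounds than are shown below. What is called first, only, known or untested is meant among the compounds shown, and "the series" means these compounds.

Measured compounds:
compound 1 `O=S(=O)(/C=C/c1ccccn1)c1ccc(F)cc1`, 3100 nM
compound 2 `O=S(=O)(/C=C/c1ncccc1Cl)c1ccc(F)cc1`, 231 nM
compound 3 `O=S(=O)(/C=C/c1ccccn1)c1ccccc1Cl`, 618 nM

All three were tested in an assay on U2OS cells for activation of nuclear factor erythroid 2-related factor 2 (Homo sapiens), read by beta-arrestin recruitment, with a stated time of 6 h; on this read-out lower numbers stand for an effect already at smaller amounts and higher numbers for an effect only at larger amounts of compound. Compound 2 differs from compound 1 by chloro in place of hydrogen on an aromatic carbon, and this gave a 13-fold lower number from compound 1 to compound 2 (1.13 log units; beyond the scatter). Compound 3 carries its chlorine on the other ring; how its core differs from that of compound 1 is not broken down here. Among the three, compound 3 gives 618 nM, which stands between the other two values.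

Compound 4 `O=S(=O)(/C=C/c1ccc(Cl)cn1)c1ccccc1Cl` is not yet measured. It differs from compound 3 by chloro in place of hydrogen on an aromatic carbon. Within the data shown here, this is the same kind of change as the one from compound 1 to compound 2, but not the same: in compound 2 the chloro sits ortho to a large group, in compound 4 it sits para to a large group. Because the earlier change gave a 13-fold lower number from compound 1 to compound 2 (1.13 log units; beyond the scatter), a lowering is expected here as well, though the changed place makes its size uncertain. The expected step is a 4.1-fold lower number from compound 3 to compound 4 (0.61 log units; beyond the scatter). Compound 4 is thus estimated at 150 nM, likely between 40 nM and 600 nM.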

Compound 4, half-maximal effective concentration: 2940 nM
Compound 4: middle estimate off by 20-fold (1.29 log units), on the low side; the whole stated range lies below it.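

In this assay, the added chloro, para to a large group, gave a 4.8-fold higher number from compound 3 to compound 4 (0.68 log units; beyond the scatter), which runs in the opposite direction to the earlier chloro step. The same kind of change therefore did not carry over from one core to the other, and the two results clearly disagree: the same change on two cores in this assay, a 13-fold lower number (1.13 log units; beyond the scatter) from compound 1 to compound 2 and a 4.8-fold higher number (0.68 log units; beyond the scatter) from compound 3 to compound 4, 64-fold (1.81 log units) apart, beyond the scatter of two such steps This does not show whether the core or the place of the chloro accounts for the disagreement, since the two pairs differ in both, and one step on each core gives no general rule for this series.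

The compounds shown leave open what chloro would do on the core of compound 1 when para to a large group, and what it would do on the core of compound 3 at the place it holds in compound 2. They also leave open how a methyl, a methoxy or an amine would compare with chloro at these places.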